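The compounds below may be only part of what the source reports. "The series", "measured", "known", "first", "only" and "open" are said of these compounds alone.

Measured compounds in this series:

- Compound 1 `CNC(=O)N1CCCc2ccc(NC(=O)c3ccc(-c4ccn(C)n4)cc3)cc21`: 830 nM
- Compound 2 `CNC(=O)N1CCCc2ccc(NC(=O)c3ccc(-c4cnn(C)c4)cc3)cc21`: 730 nM
- Compound 3 `CNC(=O)N1CCCc2ccc(NC(=O)c3ccc(-c4cn[nH]c4)cc3)cc21`: 870 nM

The three compounds share one core and differ only in the five-membered ring on the outer phenyl. In a functional assay on MV4-11 cells (Homo sapiens) for antiproliferative activity, with a stated time of 6 days (a lower number here means a stronger inhibitor, a higher number a weaker inhibitor), compound 3 sits together with the other two: a 1.0-fold higher number from compound 1 to compound 3 (0.02 log units; within the scatter) and a 1.2-fold higher number from compound 2 to compound 3 (0.08 log units; within the scatter), so nothing separates it from compound 1 or compound 2. The measured steps, a 1.1-fold lower number from compound 1 to compound 2 (0.06 log units; within the scatter) as well as the two just named, each stay within the scatter, which means that moving the methyl, removing it, or changing the attachment point of the pyrazole left the number essentially unchanged.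

Compound 4 `CNC(=O)N1CCCc2ccc(NC(=O)c3ccc(-c4cccnc4)cc3)cc21` carries the change (pyridin-3-yl in place of 1H-pyrazol-4-yl on an aromatic carbon). Among the measured compounds shown here, no measured step swaps the pyrazole for a six-membered ring, so there is no direct precedent. Given that every change on this ring so far stayed within the scatter, the expectation for compound 4 is a step of about a 1.0-fold higher number from compound 3 to compound 4 (0.01 log units; within the scatter), not beyond the scatter. Compound 4 is therefore estimated at 900 nM in this assay, with a range from 350 nM to 2500 nM.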

Compound 4, half-maximal inhibitory concentration: 1160 nM
For compound 4 the middle estimate is 1.3-fold (0.11 log units) below the measured one, and the stated range covers the measured number.
By their numbers in this assay, from the lowest: compounds 2, 1, 3 and 4 (each within the scatter of the next).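

In this assay, going from a five-membered to a six-membered aromatic ring on this aromatic carbon, para to a large group, stays within the scatter in all three comparisons (a 1.3-fold higher number from compound 3 to compound 4 (0.12 log units; within the scatter)), (a 1.6-fold higher number from compound 2 to compound 4 (0.20 log units; within the scatter)) and (a 1.4-fold higher number from compound 1 to compound 4 (0.15 log units; within the scatter)). The insensitivity seen among the pyrazoles therefore extends to pyridin-3-yl, and the loss of the hydrogen-bond donor of 1H-pyrazol-4-yl does not take the number beyond the scatter. No supporting data are available to explain this flat response.

The compounds shown carry only nitrogen-containing aromatic rings here, so it remains open whether a morpholine, a piperazine, a carboxylic acid or a plain phenyl would stay in the same band. Also open, going by these compounds, is whether any group at this position can move the number beyond the scatter.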